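Bromo to formyl on a fused bicyclic core

The source may hold more compounds than are shown below. What is called first, only, known or untested is meant among the compounds shown, and "the series" means these compounds.

Compounds measured in a functional assay on L1210 cells (Mus musculus) for cytotoxicity, with a stated time of 48 h; on this read-out higher numbers stand for weaker inhibition and lower numbers for stronger inhibition:
compound 1 `Fc1ccc(-c2nc3sc(Cc4ccc(Cl)cc4)nn3c2Br)cc1`, > 250000 nM (a limit of the assay)
compound 2 `O=c1oc2ccccc2cc1-c1nc2sc(Cc3ccc(Cl)cc3)nn2c1Br`, 5200 nM
compound 3 `O=Cc1c(-c2ccc(F)cc2)nc2sc(Cc3ccc(Cl)cc3)nn12`, 20000 nM

In this assay compound 1 gives only a limit, > 250000 nM, so its true value is not known; (the limit of > 250000 nM in this assay, at which 1 of the 3 values shown sits). Compound 3 reaches 20000 nM, and the step of an at least 12-fold lower number from compound 1 to compound 3 (1.09 log units; beyond the scatter) shows what the change formyl in place of bromo on an aromatic carbon brought. Compound 2 gives 5200 nM, the lowest number among the measured compounds, with compound 3 the nearest. How the core of compound 2 differs from that of compound 1 is not broken down here.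

Compound 4 `O=Cc1c(-c2cc3ccccc3oc2=O)nc2sc(Cc3ccc(Cl)cc3)nn12` has not yet been measured. It differs from compound 2 by formyl in place of bromo on an aromatic carbon, the same kind of change as that from compound 1 to compound 3; what differs around the place is that in compound 4 the neighbouring ring atom bears a large group, whereas in compound 3 it bears a 4-fluorophenyl group. Resting on the step of an at least 12-fold lower number from compound 1 to compound 3 (1.09 log units; beyond the scatter), which began at a limit and so may understate the true size, a step of an 8.7-fold lower number from compound 2 to compound 4 (0.94 log units; beyond the scatter) is expected from compound 2 to compound 4 in this assay. Compound 4 is therefore estimated at 600 nM, likely between 120 nM and 3000 nM.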

Compound 4, half-maximal inhibitory concentration: 890 nM
The estimate for compound 4 lay 1.5-fold (0.17 log units) below the measured number; measured number inside the range.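

In this assay, formyl in place of bromo on an aromatic carbon gives a 5.8-fold lower number from compound 2 to compound 4 (0.77 log units; beyond the scatter), so the lower number seen on the core of compound 1 recurs on a second core. This shows that the direction of the change carried over in these two pairs, and the comparison of their sizes reads: the same change on two cores in this assay, an at least 12-fold lower number (1.09 log units; beyond the scatter) from compound 1 to compound 3 and a 5.8-fold lower number (0.77 log units; beyond the scatter) from compound 2 to compound 4; the limit leaves it open whether they differ. Compound 1 stands at a limit of the assay, so these pairs do not show whether the size of the step carries over as well: the limit of > 250000 nM in this assay, at which 1 of the 4 values shown sits.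

Going by these compounds, only bromo and formyl appear at this place, so it remains open how a nitrile, a carboxylic acid or a hydroxymethyl group would compare there. On these data alone, it also remains open whether the change would lower the number on any core other than these two, or in any read-out other than this assay.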